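The source may hold more compounds than are shown below. What is called first, only, known or untested is meant among the compounds shown, and "the series" means these compounds.

Compound 1, `C/C(=C\CC/C(C)=C/CC[C@@H]1[C@@]2(C)CCC(=O)C(C)(C)[C@H]2CC[C@@]1(C)O)CC/C=C(\C)C(=O)OCc1cn(-c2ccccc2C(F)(F)F)nn1`, in a functional assay on A549 cells (Homo sapiens) for antiproliferative activity, read by MTT assay, with a stated time of 48 h (on this read-out lower numbers stand for stronger inhibition and higher numbers for weaker inhibition), reaches only the limit of the assay, > 150000 nM.
Compound 2, `C/C(=C\CC/C(C)=C/CC[C@@H]1[C@@]2(C)CCC(=O)C(C)(C)[C@H]2CC[C@@]1(C)O)CC/C=C(\C)C(=O)OCc1cn(-c2cccc(C)c2)nn1`, in this assay likewise reaches only the limit, > 150000 nM.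
Compound 3, `COc1ccc(-n2cc(COC(=O)/C(C)=C/CC/C(C)=C/CC/C(C)=C/CC[C@@H]3[C@@]4(C)CCC(=O)C(C)(C)[C@H]4CC[C@@]3(C)O)nn2)cc1`, in this assay also reaches only the limit, > 150000 nM.

Compound 3 therefore stands nowhere that a number fixes: it sits at the limit, as do the other two, which is all that the limit of > 150000 nM in this assay, at which 3 of the 3 values shown sit, records. The step to compound 4, `C/C(=C\CC/C(C)=C/CC[C@@H]1[C@@]2(C)CCC(=O)C(C)(C)[C@H]2CC[C@@]1(C)O)CC/C=C(\C)C(=O)OCc1cn(-c2ccc(C(C)(C)C)cc2)nn1`, is tert-butyl in place of methoxy on an aromatic carbon. The measured steps that bear on it are a step that the two limits leave unreadable from compound 2 to compound 3 and a step that the two limits leave unreadable from compound 1 to compound 3; the remaining one, a step that the two limits leave unreadable from compound 1 to compound 2, is no more readable. Three changes of the aryl group on the aromatic nitrogen have thus left no visible movement, and nothing points to the tert-butyl group behaving otherwise. Compound 4 is estimated at 150000 nM, with a range from 60000 nM to 400000 nM. The expected step from compound 3 is a number no higher from compound 3 to compound 4 (the limit leaves the size open), that is, no change beyond the scatter, and most likely another limit.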

Compound 4, half-maximal inhibitory concentration: > 150000 nM
Compound 4: only a limit was reported; the forecaster's own chance of this, stated with the estimate: 85%; the middle value sits exactly at the limit.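

Compound 4, like compound 1, compound 2 and compound 3, gives only a limit, so none of the steps among these compounds can be read: the limit of > 150000 nM in this assay, at which 4 of the 4 values shown sit. The compounds shown leave open whether their aryl groups on the aromatic nitrogen differ in effect at all.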